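The source may hold more compounds than are shown below. What is called first, only, known or untested is meant among the compounds shown, and "the series" means these compounds.

Compound 1 `COc1cc(-c2cc(C(=O)O)c3ccccc3n2)ccc1OCC(=O)Nc1ccc(C)cc1` in an ADME assay on HaCaT cells (Homo sapiens) for inhibition (on this read-out higher numbers stand for weaker inhibition and lower numbers for stronger inhibition), gives > 300000 nM, a limit of the assay rather than a number. Compound 2 `COc1cc(-c2cc(C(=O)O)c3ccccc3n2)ccc1OCC(=O)Nc1ccc(Cl)cc1` gives > 300000 nM in this assay, again a limit. The step from compound 1 to compound 2, chloro in place of methyl on an aromatic carbon, therefore reads a step that the two limits leave unreadable from compound 1 to compound 2. Compound 3 `COc1cc(-c2cc(C(=O)O)c3ccccc3n2)ccc1OCC(=O)Nc1ccccc1C(F)(F)F` carries 2-(trifluoromethyl)phenyl in place of 4-methylphenyl on an amide-type nitrogen. No measured step speaks to this change, and no size or direction can be read, because the limit of > 300000 nM in this assay, at which 2 of the 2 values shown sit, leaves every shown step unreadable. Compound 3 is expected at 300000 nM, between 100000 nM and 1000000 nM. The expected step reads a number no higher from compound 1 to compound 3 (the limit leaves the size open).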

Compound 3, half-maximal inhibitory concentration: 102000 nM
Compound 3: middle estimate off by 2.9-fold (0.47 log units), on the high side, and the stated range covers the measured number.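

In this assay, 2-(trifluoromethyl)phenyl on the amide-type nitrogen gives the only number among the compounds shown that is not a limit, with an at least 2.9-fold lower number from compound 1 to compound 3 (0.46 log units; beyond the scatter) and an at least 2.9-fold lower number from compound 2 to compound 3 (0.46 log units; beyond the scatter). This shows that a change at this nitrogen can move the read-out, although both steps give only a minimum size. The step between 4-methylphenyl and 4-chlorophenyl still cannot be read: the limit of > 300000 nM in this assay, at which 2 of the 3 values shown sit.

Compound 3 differs from compound 1 in both the substituent and its placement on the phenyl ring, and the compounds shown do not separate these two changes. From the compounds shown here alone, how an amine or a longer alkyl chain on this nitrogen would read remains open.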